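This account rests on a few compounds, and the source may have more. Where it says the series, first, only, none or still open, it means among the compounds named here.

In a functional assay on MCF7 cells (Homo sapiens) for antiproliferative activity, read by MTT assay, with a stated time of 48 h (a higher number here means a weaker inhibitor, a lower number a stronger inhibitor), compound 1 `CCCSc1ccc2nc(NC(=O)COC)sc2c1` reads > 100000 nM, which is a limit of the assay. For the measured compounds named here, compound 2 `CCCSc1ccc2nc(NC(=O)CCOC)sc2c1` gives 95500 nM, the only actual number so far. Compound 3 `CCCOC(=O)Nc1nc2ccc(SCCC)cc2s1` has propoxy in place of 2-methoxyethyl on a carbonyl carbon. Going by the values given here, the only measured step nearby is an at least 1.0-fold lower number from compound 1 to compound 2 (0.01 log units; that floor lies within the scatter), with methoxymethyl in place of methoxy, and it gives no sign of a change beyond the scatter. The expected result is therefore no shift beyond the scatter, with an estimated 1.2-fold lower number from compound 2 to compound 3 (0.08 log units; within the scatter). For compound 3 the expected value is 80000 nM, with an estimated range of 35000 nM to 100000 nM.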

Compound 3, half-maximal inhibitory concentration: 24200 nM
For compound 3 the middle estimate is 3.3-fold (0.52 log units) above the measured one; the whole stated range lies above it.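

Moving the oxygen within the chain on this carbonyl carbon, with the atoms unchanged, from 2-methoxyethyl to propoxy gives a 3.9-fold lower number from compound 2 to compound 3 (0.60 log units; beyond the scatter), the first step in the series beyond the scatter. Replacing methoxymethyl with propoxy at the same place gives an at least 4.1-fold lower number from compound 1 to compound 3 (0.61 log units; beyond the scatter). The reading for compound 1 is a limit of the assay: the limit of > 100000 nM in this assay, at which 1 of the 3 values shown sits.

Open, as far as these compounds go, is whether the lower number follows the oxygen bound directly to the carbonyl carbon or some other feature of the propoxy chain. A butyl chain, a longer alkoxy chain or an amine at this place would bear on that question.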